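Notes on compounds 1 to 3 in a cytotoxicity series

This account rests on a few compounds, and the source may have more. Where it says the series, first, only, none or still open, it means among the compounds named here.

Measured so far:
compound 1, `O=C1C=CC(=O)c2ncncc21`, gives 19400 nM in a functional assay on BXPC-3 cells (Homo sapiens) for cytotoxicity, read by MTT assay, with a stated time of 72 h; a higher number here means a weaker inhibitor, a lower number a stronger inhibitor
compound 2, `O=C1C(Nc2ccc(-c3ccc(F)cc3)cc2)=CC(=O)c2ncncc21`, gives 4400 nM in this assay

Going by the values given here, only two numbers are known, and compound 2 holds the lower of them. The nearest number is that of compound 1, which is higher by a gap beyond the usual scatter, so compound 2 is the stronger inhibitor of the pair in this assay. Among the compounds with values here, the difference between the two structures is more than a single change, so no single step can be drawn from it.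

Compound 3, `CCOC(=O)c1ccc(NC2=CC(=O)c3ncncc3C2=O)cc1`, has not yet been measured. It differs from compound 2 at one place: ethoxycarbonyl in place of 4-fluorophenyl on an aromatic carbon. Within the data shown here, no pair of measured compounds shows the effect of such a swap, so the expectation rests only on compound 2 and on the size of the change, and the expected step in this assay is small, most likely within the scatter or a mild weakening.

Compound 3 is estimated at 6000 nM in this assay, with a range from 2000 nM to 20000 nM. This estimate amounts to an expected step of a 1.4-fold higher number from compound 2 to compound 3 (0.13 log units; within the scatter), not clearly beyond the scatter.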

Compound 3, half-maximal inhibitory concentration: 5900 nM
Compound 3: middle estimate off by 1.0-fold (0.01 log units), on the high side; the measured number falls inside the stated range.
By their numbers in this assay, from the lowest: compounds 2 and 3 (each within the scatter of the next); then compound 1.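

Ethoxycarbonyl in place of 4-fluorophenyl on an aromatic carbon, para to a large group, gives a 1.3-fold higher number from compound 2 to compound 3 (0.13 log units; within the scatter) in this assay and provides the first comparison in the series that differs in one place. Within the scatter, this assay does not separate the two groups at this position. The swap replaces 7 heavy atoms and a six-membered aromatic ring of carbon only with 5 heavy atoms, no ring and 2 hydrogen-bond acceptors, and this change in make-up comes with no step beyond the scatter. Nothing measured on these compounds bears on why the two groups read alike.

Going by these compounds alone, whether a carboxylic acid, a primary amide or a methyl ester at this place would read like ethoxycarbonyl stays open, since a single step covers only one pair of groups. Also open, from the compounds shown here alone, is whether an amine or a longer alkyl chain here would stay within the scatter of compound 2 and compound 3, or would give a step beyond it.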